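This account rests on a few compounds, and the source may have more. Where it says the series, first, only, none or still open, it means among the compounds named here.

Among the compounds with values here, in a functional assay on MCF7 cells (Homo sapiens) for antiproliferative activity, read by MTT assay, with a stated time of 72 h (on this read-out lower numbers stand for stronger inhibition and higher numbers for weaker inhibition), compound 2 `COc1cc(-n2cnc3ccc(-c4cccc(F)c4)cc32)cc(OC)c1OC` gives 2350 nM, the second highest of the three numbers measured so far. Compound 1 `COc1cc(-n2cnc3ccc(-c4cccc(N)c4)cc32)cc(OC)c1OC` gives 180 nM, and compound 3 `COc1cc(-n2cnc3ccc(-c4ccc(O)cc4)cc32)cc(OC)c1OC` gives 4160 nM. The step of a 13-fold higher number from compound 1 to compound 2 (1.12 log units; beyond the scatter) is large, as is a 23-fold higher number from compound 1 to compound 3 (1.36 log units; beyond the scatter), whereas a 1.8-fold higher number from compound 2 to compound 3 (0.25 log units; within the scatter) stays within the scatter. Compound 4 `COc1cc(-n2cnc3ccc(-c4ccc(C)cc4F)cc32)cc(OC)c1OC` differs from compound 2 in one place: 2-fluoro-4-methylphenyl in place of 3-fluorophenyl on an aromatic carbon. Within the data shown here, no measured step repeats this exact change; of the measured steps, only a 1.8-fold higher number from compound 2 to compound 3 (0.25 log units; within the scatter) also exchanges one substituted phenyl for another without an amino group, and it stays within the scatter. Compound 4 is therefore expected to move only modestly, with the step of a 1.1-fold higher number from compound 2 to compound 4 (0.03 log units; within the scatter) expected to remain within or near the scatter. The value of compound 4 is estimated at 2500 nM, with a range from 800 nM to 8000 nM.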

Compound 4, half-maximal inhibitory concentration: 56 nM
Compound 4: middle estimate off by 45-fold (1.65 log units), on the high side, and the stated range ends above it.
By their numbers in this assay, from the lowest: compound 4; then compound 1; then compounds 2 and 3 (each within the scatter of the next).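

The aryl group at this position can lower the number far more than compounds 1 to 3 showed: the step to 2-fluoro-4-methylphenyl gives a 42-fold lower number from compound 2 to compound 4 (1.62 log units; beyond the scatter) and a 74-fold lower number from compound 3 to compound 4 (1.87 log units; beyond the scatter), so an amino group is not needed for a low number. It even goes past the 3-aminophenyl group, with a 3.2-fold lower number from compound 1 to compound 4 (0.51 log units; beyond the scatter) as the step. Nothing measured here accounts for this gain. As far as these compounds go, the change moves the fluorine and adds the methyl together, so the share of each remains open. Also open, from the compounds shown here alone, is whether a chloro or methoxy group in place of that methyl would keep the number low.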